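This account rests on a few compounds, and the source may have more. Where it says the series, first, only, none or still open, it means among the compounds named here.

Compound 1 `CC(CCc1cccc(OCc2ccc3ccccc3n2)c1)Cc1nnn[nH]1`: 17 nM
Compound 2 `CC(CCCC(=O)O)c1cccc(OCc2ccc3ccccc3n2)c1`: 90 nM
Compound 3 `O=C(O)CCCCc1cccc(OCc2ccc3ccccc3n2)c1`: 100 nM

Of these three, compound 3 gives the highest number in an assay on membranes from lung (Cavia porcellus) for binding affinity to cysteinyl leukotriene receptor (Homo sapiens) (a higher number here means a weaker inhibitor, a lower number a stronger inhibitor), meaning the weakest binding. The gap to compound 2 is small: a 1.1-fold higher number from compound 2 to compound 3 (0.05 log units; within the scatter). The gap to compound 1 is larger: a 5.9-fold higher number from compound 1 to compound 3 (0.77 log units; beyond the scatter).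

Compound 4 `CC(CCCc1cccc(OCc2ccc3ccccc3n2)c1)C(=O)O` differs from compound 3 in one place: methyl in place of hydrogen on a saturated chain carbon bound to a carbonyl carbon and a saturated chain carbon. For the measured compounds named here, the only measured step that bears on adding a methyl to this chain, a 1.1-fold higher number from compound 2 to compound 3 (0.05 log units; within the scatter), placed the methyl elsewhere on the chain and stayed within the scatter. A step of a similar size is therefore expected here, a 1.1-fold lower number from compound 3 to compound 4 (0.05 log units; within the scatter), with no clear direction. The estimate for compound 4 in this assay is 90 nM, in the range 35 nM to 250 nM.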

Compound 4, inhibition constant: 85 nM
Estimate against measurement, compound 4: 1.1-fold (0.02 log units) above; the measured number falls inside the stated range.
By their numbers in this assay, from the lowest: compound 1; then compounds 4, 2 and 3 (each within the scatter of the next).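

In this assay, a methyl on the saturated chain carbon bound to a carbonyl carbon stays within the scatter (a 1.2-fold lower number from compound 3 to compound 4 (0.07 log units; within the scatter)). Placing the methyl on the carbon bound to the aromatic carbon instead also makes no clear difference (a 1.1-fold lower number from compound 2 to compound 4 (0.02 log units; within the scatter)). Compound 1, with its tetrazole, remains clearly apart from this carboxylic acid (a 5.0-fold higher number from compound 1 to compound 4 (0.70 log units; beyond the scatter)).

On these data alone, whether an ethyl or a fluorine at this chain carbon would shift binding remains open. Nothing available explains why these methyl positions look alike.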